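This account rests on a few compounds, and the source may have more. Where it says the series, first, only, none or still open, it means among the compounds named here.

Compound 1 `CON=C1CCC(N(C)N2CCN(c3nc(=O)c4cc(C(F)(F)F)cc([N+](=O)[O-])c4s3)CC2)CC1` and compound 2 `O=c1nc(N2CCN(NCc3ccc(Cl)cc3)CC2)sc2c([N+](=O)[O-])cc(C(F)(F)F)cc12` differ only at an amine nitrogen in a ring. In an ADME assay on Vero cells (Chlorocebus sabaeus) for cytotoxicity, read by MTT assay, with a stated time of 72 h (on this read-out lower numbers stand for higher toxicity in this test and higher numbers for lower toxicity in this test), compound 1 gives > 64 ug/mL, which is a limit of the test and not a measured number. In this assay compound 2 likewise gives > 64 ug/mL, again a limit rather than a value. The step that the two limits leave unreadable from compound 1 to compound 2 is therefore of unreadable size, and compound 2 stands at the limit of > 64 ug/mL in this assay, at which 2 of the 2 values shown sit, with nothing in the measured material placing it anywhere else. Compound 3 `O=c1nc(N2CCN(NCc3ccc(Br)cc3)CC2)sc2c([N+](=O)[O-])cc(C(F)(F)F)cc12` is the next member: bromo in place of chloro on an aromatic carbon. Within the data shown here, of the measured steps only the one from compound 1 to compound 2 touches the same part of the molecule, and it is unreadable, so it gives no size for the present change; the evidence is simply that both values so far sit at the limit of > 64 ug/mL in this assay, at which 2 of the 2 values shown sit. No step beyond the scatter is expected in this assay, in either direction, and the most likely outcome is once more the limit. For compound 3 the estimate in this assay is 100 ug/mL, within 50 ug/mL to 250 ug/mL, which means an expected step that the limit leaves unreadable from compound 2 to compound 3 of no consequence.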

Compound 3, half-maximal cytotoxic concentration: > 64 ug/mL
Compound 3 gave a limit, no number (the forecaster's own chance of this, stated with the estimate: 85%); the middle value does not contradict the limit.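

In this assay compound 3 gives > 64 ug/mL as a limit and not a number. Among these compounds, no step among compound 1, compound 2 and compound 3 can be read, and the bromo for chloro change has no readable size: the limit of > 64 ug/mL in this assay, at which 3 of the 3 values shown sit. The compounds shown leave open where the true values lie, and which change, if any, would bring a value inside the range of the test.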